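A few compounds are considered here, and "the series" means these few. Any claim that something is new, unique, unknown or untested is made for them only; others in the source may bear on it.

Measured so far:
- compound 1 `CC(C)n1cnc2c(NC(=N)N)nc(NCCCCCCO)nc21`: 5200 nM
- compound 2 `CC(C)[C@H](N)COc1nc(NC(=N)N)c2ncn(C(C)C)c2n1`: 3400 nM

In a functional assay on MCF7 cells (Homo sapiens) for inhibition, read by fluorescence, with a stated time of 72 h (on this read-out higher numbers stand for weaker inhibition and lower numbers for stronger inhibition), compound 2 gives 3400 nM, within the scatter of compound 1. Compound 3 `CC(C)n1cnc2c(NC(=N)N)nc(OC[C@H]3CCCN3)nc21` differs from compound 2 as follows: pyrrolidin-2-yl in place of 1-amino-2-methylpropyl on a saturated chain carbon bound to an oxygen on an aromatic ring. It carries pyrrolidin-2-yl in place of 1-amino-2-methylpropyl on a saturated chain carbon bound to an oxygen on an aromatic ring. For the measured compounds named here, only one measured step bears on this change: a 1.5-fold lower number from compound 1 to compound 2 (0.18 log units; within the scatter), which exchanged the whole side chain. A step beyond the scatter is therefore not expected in this assay. The expected change is a 1.0-fold higher number from compound 2 to compound 3 (0.01 log units; within the scatter). For compound 3 the estimate is 3500 nM, with an expected range of 1300 nM to 9500 nM.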

Compound 3, half-maximal inhibitory concentration: > 100000 nM
Compound 3: a limit, no number; the forecaster's own chance of this, stated with the estimate: 5%; middle value at least 28-fold (1.45 log units) from the limit.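

Compound 3 stands at a limit of this assay, which is not a number: the limit of > 100000 nM in this assay, at which 1 of the 3 values shown sits. At this saturated chain carbon the side chain therefore tolerates less than the earlier pair suggested: pyrrolidin-2-yl in place of 1-amino-2-methylpropyl, two groups with the same count of heavy atoms, gives an at least 29-fold higher number from compound 2 to compound 3 (1.46 log units; beyond the scatter). The comparison with the (6-hydroxyhexyl)amino side chain is also beyond the scatter, with an at least 19-fold higher number from compound 1 to compound 3 (1.28 log units; beyond the scatter).

The compounds shown leave open whether a piperidin-2-yl ring or an unbranched aminoethyl chain on the same oxygen would read like compound 2. They also do not tell what causes the step.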